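A few compounds are considered here, and "the series" means these few. Any claim that something is new, unique, unknown or untested is made for them only; others in the source may bear on it.

Measured compounds and their values:
compound 1, `Cc1cc(/C=C/C(=O)O)cc(C)c1Oc1ccc([N+](=O)[O-])c(Nc2ccc(C#N)cc2)n1`: 27800 nM
compound 2, `Cc1cc(/C=C/C(=O)O)cc(C)c1Oc1ccc(N)c(Nc2ccc(C#N)cc2)n1`: 18000 nM
compound 3, `Cc1cc(/C=C/C#N)cc(C)c1Oc1cc(Nc2ccc(C#N)cc2)c(N)cc1[N+](=O)[O-]`: > 47000 nM

All three were tested in an ADME assay on TZM cells (Homo sapiens) for cytotoxicity, read by XTT assay, with a stated time of 4 days; on this read-out higher numbers stand for lower toxicity in this test and lower numbers for higher toxicity in this test. Compound 1 gives 27800 nM and compound 2 gives 18000 nM in this assay. The two differ by amino in place of nitro on an aromatic carbon, and this change gave a 1.5-fold lower number from compound 1 to compound 2 (0.19 log units; within the scatter). For compound 3 the read-out in this assay is a limit of the assay and not a number, > 47000 nM. The record holds (the limit of > 47000 nM in this assay, at which 1 of the 3 values shown sits). How the core of compound 3 differs from the core of compound 1 is not broken down here.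

Compound 4, `Cc1cc(/C=C/C#N)cc(C)c1Oc1cc(Nc2ccc(C#N)cc2)c(N)cc1N`, has not yet been tested in this assay. It differs from compound 3 by amino in place of nitro on an aromatic carbon. Within the data shown here, this is the same kind of change as the one from compound 1 to compound 2, but its surroundings are not the same: in compound 1 the replaced nitro sits on a six-membered aromatic ring with 1 nitrogen, ortho to a (4-cyanophenyl)amino group, two atoms from the ring nitrogen and para to a large group, whereas in compound 3 it sits on a six-membered aromatic ring of carbon only, ortho to a large group, meta to an amino group and para to a (4-cyanophenyl)amino group. Among the measured compounds shown here, since compound 3 gave only a limit, the expectation rests on the one measured step, and the step from compound 3 to compound 4 in this assay is expected to be an at least 1.1-fold lower number from compound 3 to compound 4 (0.07 log units; that floor lies within the scatter), of a size like that seen for compound 1 to compound 2 in a 1.5-fold lower number from compound 1 to compound 2 (0.19 log units; within the scatter). Compound 4 is therefore estimated at 40000 nM in this assay, with a range expected from 18000 nM to 90000 nM.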

Compound 4, half-maximal cytotoxic concentration: 14400 nM
Beside the measured number, compound 4's estimate is 2.8-fold (0.44 log units) above it, outside the stated range (below it).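

In this assay, amino in place of nitro on an aromatic carbon of a six-membered aromatic ring of carbon only gave an at least 3.2-fold lower number from compound 3 to compound 4 (0.51 log units; beyond the scatter), so on this core the change lowers the number by more than the usual scatter. Set beside the earlier step, a 1.5-fold lower number from compound 1 to compound 2 (0.19 log units; within the scatter), the change runs the same way on both cores, but only the newer step lies beyond the scatter, and this pair of steps does not settle whether its size carries over from one core to the other: the same change on two cores in this assay, a 1.5-fold lower number (0.19 log units; within the scatter) from compound 1 to compound 2 and an at least 3.2-fold lower number (0.51 log units; beyond the scatter) from compound 3 to compound 4; the limit leaves it open whether they differ. As far as these compounds go, compound 3 holds a limit of the assay and not a number, so the full size of its step stays unknown, and two cores show no rule for the wider series: the limit of > 47000 nM in this assay, at which 1 of the 4 values shown sits.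

The compounds shown leave open which of the features separating the two cores governs the size of the step, since each step was read on only one core. They also leave open what an acetylamino group or a chlorine would do in place of the nitro, and whether the step would hold on a core with a longer chain in place of the one carrying the nitrile.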